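The source may hold more compounds than are shown below. What is called first, only, known or untested is meant among the compounds shown, and "the series" means these compounds.

The measured compounds:

Compound 1, `COc1ccc2c(=O)c(-c3ccc(Oc4ccc(OC(F)(F)F)cc4)cc3)c(C)[nH]c2c1` — > 10000 nM
Compound 2, `CCCCCCCc1c(C)[nH]c2cc(OC)c(Cl)cc2c1=O` — "not determined" (no result reported)
Compound 3, `Cc1[nH]c2ccccc2c(=O)c1-c1ccc(Oc2ccccc2)cc1` — > 10000 nM

In an ADME assay on HepG2 cells (Homo sapiens) for cytotoxicity, read by resazurin assay, with a stated time of 24 h (a higher number here means a weaker inhibitor, a lower number a stronger inhibitor), compound 1 gives > 10000 nM, and this is a limit of the assay, not a number. Compound 3 gives > 10000 nM in this assay, again a limit. For compound 2 this assay reports "not determined" (no result reported), so no value exists for it. Of the values shown, then, two sit at the same limit and the third is missing. Within the data shown here, no two of the measured compounds differ in only one place, so no measured step exists to show what one change does; what is known is the limit of > 10000 nM in this assay, at which 2 of the 3 values shown sit.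

Compound 4, `COc1cc2[nH]c(C)c(-c3ccc(Oc4ccc(OC(F)(F)F)cc4)cc3)c(=O)c2cc1Cl`, differs from compound 1 by chloro in place of hydrogen on an aromatic carbon. With compound 1 standing at a limit, the expectation for this assay is a step of no size beyond the scatter, and in practice compound 4 is expected to stand at the same limit rather than at a readable number. The step from compound 1 to compound 4 is estimated as a step that the limit leaves unreadable from compound 1 to compound 4. Compound 4 is therefore expected to give about 15000 nM in this assay, with a range from 8000 nM to 40000 nM.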

Compound 4, half-maximal inhibitory concentration: > 10000 nM
Compound 4 ended at the assay's limit; the forecaster's own chance of this, stated with the estimate: 80%; the middle value lies beyond the limit too.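

Compound 1 and compound 4 both stand at a limit of this assay rather than at a readable number, so no size can be read for the step of chloro in place of hydrogen. The compounds shown leave open what any single change does to a readable value, since the results mostly end at one point: the limit of > 10000 nM in this assay, at which 3 of the 4 values shown sit.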